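Swapping the pyridine for a cyanothiophene at the ether end

The compounds below may be only part of what the source reports. "The series", "measured", "known", "first", "only" and "open" are said of these compounds alone.

Of the compounds shown here, three sharing one core have been measured in a functional assay on HEK293 cells for positive allosteric modulation of metabotropic glutamate receptor 5 (Homo sapiens), read by FLIPR and calcium flux; on this read-out lower numbers stand for an effect already at smaller amounts and higher numbers for an effect only at larger amounts of compound. Compound 1 `O=C(COCc1ccccc1)N1CCN(c2ccc(F)cc2Cl)CC1` gives 270 nM, compound 2 `O=C(COCc1ccncc1)N1CCN(c2ccc(F)cc2F)CC1` gives 4600 nM, and compound 3 `O=C(COCc1cccnc1)N1CCN(c2ccc(Cl)cc2Cl)CC1` gives 1090 nM. Compound 3 thus sits between the other two, with both gaps beyond the usual scatter: compound 1 reaches its effect at a smaller amount, compound 2 only at a larger one.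

Compound 4 `N#Cc1ccc(COCC(=O)N2CCN(c3ccc(Cl)cc3Cl)CC2)s1` differs from compound 3 in one place: 5-cyanothiophen-2-yl in place of pyridin-3-yl on a saturated chain carbon bound to an oxygen on a saturated carbon. For the measured compounds named here, no measured pair shows this same change, so nothing anchors its size. The step from compound 3 to compound 4 is expected to be small, at most a modest move toward a lower number, as a 1.6-fold lower number from compound 3 to compound 4 (0.19 log units; within the scatter). Compound 4 is therefore expected to give about 700 nM in this assay, within roughly 200 nM to 3000 nM.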

Compound 4, half-maximal effective concentration: 210 nM
The estimate for compound 4 lay 3.3-fold (0.52 log units) above the measured number, within the range that was stated.
By their numbers in this assay, from the lowest: compounds 4 and 1 (each within the scatter of the next); then compound 3; then compound 2.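

In this assay, placing 5-cyanothiophen-2-yl where pyridin-3-yl stood gives a 5.2-fold lower number from compound 3 to compound 4 (0.72 log units; beyond the scatter) and so moves the number beyond the usual scatter. This shows that the ring at this position on the chain can change the result, and that a pyridine is not needed there. Nothing at hand explains the size of this step.

On these data alone, it remains open whether the nitrile or the thiophene ring accounts for the step. A plain thiophen-2-yl or a 5-methylthiophen-2-yl at this position would help to tell the two apart.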